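Cyclobutyl to 2-methylcyclopropyl on the carbonyl of compound 2

The source may hold more compounds than are shown below. What is called first, only, known or untested is meant among the compounds shown, and "the series" means these compounds.

Within the data shown here, compound 2 `O=C(C1CCC1)N1CC2CC(C1)N2` gives 16 nM in an assay on SH-EP1 cells for displacement of a labelled ligand from Neuronal acetylcholine receptor; alpha4/beta2 (Homo sapiens), read by scintillation counting (on this read-out lower numbers stand for stronger inhibition and higher numbers for weaker inhibition), the lowest of the three numbers so far. Compound 3 `O=C(C1CCCC1)N1CC2CC(C1)N2`, the same core with cyclopentyl on the carbonyl, gives 160 nM, a gap beyond the scatter. Compound 1 `O=C(C1CC1)N1CC2CC1CN2`, a differently joined core carrying cyclopropyl, gives 2800 nM, the furthest from compound 2. Compound 4 `C[C@@H]1C[C@H]1C(=O)N1CC2CC(C1)N2` differs from compound 2 in one place: 2-methylcyclopropyl in place of cyclobutyl on a carbonyl carbon. Among the measured compounds shown here, no measured pair shows this exchange, and the change of core between compound 1 and compound 2 prevents reading the cyclopropyl effect directly. A modest weakening is expected, a 2.5-fold higher number from compound 2 to compound 4 (0.40 log units; beyond the scatter), smaller than the cyclopentyl step. Compound 4 is estimated at 40 nM, within 10 nM to 160 nM.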

Compound 4, inhibition constant: 1 nM
Beside the measured number, compound 4's estimate is 40-fold (1.60 log units) above it; measured number below the stated range.
By their numbers in this assay, from the lowest: compound 4; then compound 2; then compound 3; then compound 1.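

In this assay, the position on a carbonyl carbon proves highly sensitive to how the same four carbons are arranged: 2-methylcyclopropyl in place of cyclobutyl gives a 16-fold lower number from compound 2 to compound 4 (1.20 log units; beyond the scatter), a large step. Heavy-atom count, donors, acceptors and charge of the group all stay the same, so these counts do not separate the two groups. No available evidence accounts for this step.

Open, going by these compounds, is whether the three-membered ring alone, the methyl on it, or its two defined stereocentres carry the step. On these data alone, how a 2-ethylcyclopropyl group or an unsubstituted cyclopropyl on this core would read also remains open.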